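This account rests on a few compounds, and the source may have more. Where it says the series, first, only, none or still open, it means among the compounds named here.

Three compounds of the shared core have numbers in a functional assay on EKVX cells (Homo sapiens) for inhibition, read by sulforhodamine B assay, with a stated time of 48 h, tested at 10 uM; on this read-out higher numbers stand for more inhibition at the one concentration tested (going by the name of the read-out) and lower numbers for less inhibition. Compound 1 `c1ccc(-c2cn3ccnc3c(-c3ccc4ncn(C5CCCCC5)c4c3)n2)cc1` gives 24.2%, compound 2 `O=Cc1ccc(-c2cn3ccnc3c(-c3ccc4ncn(C5CCCCC5)c4c3)n2)cc1` gives 20.9%, and compound 3 `Fc1ccc(-c2cn3ccnc3c(-c3ccc4ncn(C5CCCCC5)c4c3)n2)cc1` gives 10.5%. Compound 2 sits close to compound 1, since a number 3.3 percentage points lower from compound 1 to compound 2 (within the scatter), and apart from compound 3, since a number 10.4 percentage points lower from compound 2 to compound 3 (beyond the scatter). Compound 4 `Clc1ccc(-c2cn3ccnc3c(-c3ccc4ncn(C5CCCCC5)c4c3)n2)cc1` differs from compound 2 by chloro in place of formyl on an aromatic carbon. The step that bears most directly on this is the one with fluoro in place of formyl, a number 10.4 percentage points lower from compound 2 to compound 3 (beyond the scatter); the related step of a number 13.7 percentage points lower from compound 1 to compound 3 (beyond the scatter) points the same way. A second halogen in place of the formyl is therefore expected to lower the number modestly, about a number 8.9 percentage points lower from compound 2 to compound 4 (within the scatter). Compound 4 is estimated at 12%, in the range 3% to 24%.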

Compound 4, a percentage reported as inhibition, at one concentration (the size of the read-out at that concentration, not a potency): 13.1%
Compound 4: middle estimate off by 1.1 percentage points, on the low side, within the range that was stated.
By their numbers in this assay, from the lowest: compounds 3, 4, 2 and 1 (each within the scatter of the next, the first and the last beyond it).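

In this assay chloro at this position, para to a large group, gives a number 11.1 percentage points lower from compound 1 to compound 4 (beyond the scatter) and so joins fluoro as a second halogen set apart from hydrogen. Chloro and fluoro are not told apart, with a number 2.6 percentage points higher from compound 3 to compound 4 (within the scatter) as the step between them, and a number 7.8 percentage points lower from compound 2 to compound 4 (within the scatter) leaves chloro not separated from formyl, although fluoro was. Nothing measured here accounts for these numbers.

Open, on these data alone, is whether an amine, a carboxylic acid or a methoxy group at this position would stand with hydrogen and formyl or with the two halogens.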